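Acetamido on the phenoxy ring of the shared core

A few compounds are considered here, and "the series" means these few. Any claim that something is new, unique, unknown or untested is made for them only; others in the source may bear on it.

Three compounds of this series carry a measured value. Compound 1 `COc1ccc(C2Nc3ccc(O)cc3C(=O)N2Cc2ccccc2)cc1COc1ccc(NC(C)=O)cc1` gives 93.3% in a functional assay on HEK-EM293 cells for agonist activity at Thyrotropin receptor (Homo sapiens), read by ELISA and cAMP accumulation, with a stated time of 1 h; on this read-out higher numbers stand for larger maximal responses and lower numbers for smaller maximal responses. Compound 2 `CC(=O)Nc1ccc(OCc2cccc(C3Nc4ccccc4C(=O)N3Cc3ccccc3)c2)cc1` gives 36.8% in this assay. Compound 3 `COc1ccc(C2Nc3ccccc3C(=O)N2Cc2ccccc2)cc1COc1ccccc1` gives 25.6% in this assay, the lowest of the three numbers: compound 2 lies above it beyond the scatter, and compound 1 further above, also beyond the scatter. No two of these compounds differ in a single place, so no clean step is available. Compound 4 `COc1ccc(C2Nc3ccccc3C(=O)N2Cc2ccccc2)cc1COc1cccc(NC(C)=O)c1` is not yet measured. It differs from compound 3 by acetamido in place of hydrogen on an aromatic carbon, on the ring that in compound 3 carries no substituent. Both compounds that bear an acetamido group on the phenoxy ring, compound 1 with 93.3% and compound 2 with 36.8%, sit above compound 3, although neither comparison is a one-place step. On that basis an upward step beyond the scatter is expected, smaller than the gap to compound 1. For compound 4 the expected value in this assay is 45%, in the range 25% to 75%, an estimated step of a number 19.4 percentage points higher from compound 3 to compound 4 (beyond the scatter).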

Compound 4, largest response reached (Emax), in percent of the reference or control that the assay uses: 24.8%
The estimate for compound 4 lay 20.2 percentage points above the measured number; the measured number lies below the stated range.
By their numbers in this assay, from the lowest: compounds 4 and 3 (each within the scatter of the next); then compound 2; then compound 1.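

Acetamido in place of hydrogen, on an aromatic carbon of the phenoxy ring and meta to a large group, gives a number 0.8 percentage points lower from compound 3 to compound 4 (within the scatter) in this assay. Among these compounds, this is the first one-place step, and at this position on the shared core the change leaves the maximal response within the scatter; the steps to compound 1 and compound 2 cannot be read, as each differs from these compounds in more than one place. No measurement here offers an explanation for this result.

On these data alone, whether an amine or a carboxylic acid at this same place would give a number beyond the scatter of compound 3 remains open. Also open, as far as these compounds go, is what the hydroxy group of compound 1 contributes on its own.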